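Swapping a chloro for a small ring on a shared core

The source may report more compounds than this note shows. Statements on the series, on what has been measured and on what is new or still open speak of the compounds shown alone.

Measured so far:
- compound 1, `Nc1ccc2cc(Cl)ccc2n1`: 76000 nM
- compound 2, `Nc1ccc2cc(C3OCCCO3)ccc2n1`: 26000 nM

Both compounds were tested in an assay on isolated protein for displacement of a labelled ligand from tyrosine-protein kinase TEC (Mus musculus), read by fluorescence polarization; a lower number here means that less compound is needed, a higher number that more compound is needed for the effect. For the measured compounds named here, of the two numbers, compound 1 gives the highest, 76000 nM, and compound 2 gives a number beyond the scatter below it; what separates them is the group on the shared core, a chloro in compound 1 and a six-membered ring with two oxygens in compound 2, but no step between them has been worked out, so only their two values speak.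

Compound 3, `Nc1ccc2cc(C3OCCO3)ccc2n1`, has not yet been tested in this assay. It differs from compound 1 by 1,3-dioxolan-2-yl in place of chloro on an aromatic carbon. The group that enters is a close relative of the ring found in compound 2, one atom smaller. On that basis the step is expected to run downward, toward the number seen for compound 2, since compound 2 gives 26000 nM. The step from compound 1 to compound 3 is expected to be a 2.5-fold lower number from compound 1 to compound 3 (0.40 log units; beyond the scatter). Compound 3 is estimated at 30000 nM, within a range of 12000 nM to 75000 nM.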

Compound 3, half-maximal effective concentration: 34000 nM
Compound 3: the middle estimate sits 1.1-fold (0.05 log units) below what was measured; measured number inside the range.
By their numbers in this assay, from the lowest: compounds 2 and 3 (each within the scatter of the next); then compound 1.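

Putting 1,3-dioxolan-2-yl in place of chloro on this aromatic carbon gives, in this assay, a 2.2-fold lower number from compound 1 to compound 3 (0.35 log units; beyond the scatter), a modest step, and the first at this position that can be read directly between two compounds differing in one place. Compound 2 gives 26000 nM and compound 3 gives 34000 nM, two values within the scatter of each other, so this assay does not separate the five-membered ring from the six-membered ring with two oxygens. Nothing measured here accounts for the step from the chloro compound to the ring compound.

The compounds shown cannot tell whether the ring itself or its two oxygens matter, since each ring tested carries both, and a carbon-only cyclopentyl ring or an open methoxymethyl chain would pull those two apart. On these data alone, how an amine or a carboxylic acid would read on the same carbon is also open, as is whether any group there can shift the number much further than this modest step.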